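From Dibromophenyl to Difluorophenyl at the Assay Limit

The source may report more compounds than this note shows. Statements on the series, on what has been measured and on what is new or still open speak of the compounds shown alone.

In a functional assay on HFF cells (Homo sapiens) for cytotoxicity (on this read-out higher numbers stand for weaker inhibition and lower numbers for stronger inhibition), compound 1 `Cc1cccc(/C=C2\SC(=S)N(NS(=O)(=O)c3ccccc3)C2=O)c1` returns only a limit, > 100000 nM. Compound 2 `O=C1/C(=C/c2ccc(Br)c(Br)c2)SC(=S)N1NS(=O)(=O)c1ccccc1` also returns only a limit, > 100000 nM, so its standing cannot be told as a number. Compound 3 `O=C1/C(=C/c2ccc(F)cc2F)SC(=S)N1NS(=O)(=O)c1ccccc1` differs from compound 2 in one place: 2,4-difluorophenyl in place of 3,4-dibromophenyl on a double-bonded chain carbon bound to a double-bonded ring carbon. The 2,4-difluorophenyl thus takes the place of the 3,4-dibromophenyl, and the rest of the structure stays the same. For the measured compounds named here, the one measured step that bears on this change, at the same place, is a step that the two limits leave unreadable from compound 1 to compound 2. It has no readable size and gives no direction. The whole record so far is the limit of > 100000 nM in this assay, at which 2 of the 2 values shown sit. With no number to build on, no shift beyond the scatter is expected in this assay, and the estimated move is a number no higher from compound 2 to compound 3 (the limit leaves the size open). For compound 3 the expected value is 100000 nM, with an estimated range of 50000 nM to 200000 nM.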

Compound 3, half-maximal inhibitory concentration: > 100000 nM
Compound 3 was reported as a limit (the forecaster's own chance of this, stated with the estimate: 80%); the middle value lies on the limit itself.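

Compound 1, compound 2 and compound 3 all return only a limit, so no step among them can be read: the limit of > 100000 nM in this assay, at which 3 of the 3 values shown sit.

The compounds shown leave open whether 3-methylphenyl, 3,4-dibromophenyl and 2,4-difluorophenyl differ at all in this assay.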